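Notes on compound 3: an amide arm in place of the ester

The source may hold more compounds than are shown below. What is called first, only, known or untested is meant among the compounds shown, and "the series" means these compounds.

Measured so far:
compound 1 `CCOc1cc2ncnc(Nc3ccc(F)c(Cl)c3)c2cc1OC(=O)CSc1cccnc1` in a functional assay on NCI-H1975 cells (Homo sapiens) for inhibition, read by MTT assay, with a stated time of 72 h (a higher number here means a weaker inhibitor, a lower number a stronger inhibitor), gives 3000 nM
compound 2 `CCOc1cc2ncnc(Nc3ccc(F)c(Cl)c3)c2cc1OC(=O)CSc1nc2ccccc2n1C` in this assay gives 9100 nM

Compound 1 holds the lowest of the two numbers; the nearest is compound 2, a 3.0-fold higher number from compound 1 to compound 2 (0.48 log units; beyond the scatter). Compound 3 `CCOc1cc2ncnc(Nc3ccc(F)c(Cl)c3)c2cc1NC(=O)COC(C)=O` differs from compound 1 as follows: ((acetoxymethyl)carbonyl)amino in place of ((((pyridin-3-yl)sulfanyl)methyl)carbonyl)oxy on an aromatic carbon. Going by the values given here, the single measured step only swaps the group on the sulfur and keeps the ester arm, so it does not bear on this change, which removes that whole arm. Among the compounds with values here, with no step to rest on, compound 3 is expected near compound 1, with a wide range, a 1.7-fold higher number from compound 1 to compound 3 (0.22 log units; within the scatter); the estimate is 5000 nM (from 1500 nM to 16000 nM).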

Compound 3, half-maximal inhibitory concentration: 3400 nM
For compound 3 the middle estimate is 1.5-fold (0.17 log units) above the measured one, within the range that was stated.
By their numbers in this assay, from the lowest: compounds 1 and 3 (each within the scatter of the next); then compound 2.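

On this aromatic carbon, the ((((pyridin-3-yl)sulfanyl)methyl)carbonyl)oxy arm gives way to ((acetoxymethyl)carbonyl)amino with a 1.1-fold higher number from compound 1 to compound 3 (0.05 log units; within the scatter) in this assay. In this pair, the pyridine ring and the sulfur are therefore not required for a number at this level, although the linking oxygen and the end group change together and cannot be separated. Nothing measured accounts for this result.

An amide arm ending in pyridin-3-ylsulfanyl would separate linker from end group. Also open, from the compounds shown here alone, is how a free hydroxyl or a dimethylamino group in place of the acetoxy would read.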